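This account rests on a few compounds, and the source may have more. Where it says the series, first, only, none or still open, it means among the compounds named here.

Measured compounds:
compound 1, `COc1cccc(OC)c1OCCNCCOc1ccccc1OCc1ccccc1Cl`, gives 0.562 nM;
compound 2, `COc1cccc(OC)c1OCCNCCOc1ccccc1OCc1ccccc1C`, gives 0.794 nM;
compound 3, `COc1cccc(OC)c1OCCNCCOc1ccccc1OCc1cccc(C)c1`, gives 0.251 nM.

These three values come from an assay on CHO cells for displacement of a labelled ligand from Alpha-1B adrenergic receptor (Homo sapiens); a higher number here means a weaker inhibitor, a lower number a stronger inhibitor. Compound 3 has the lowest number of the three; compound 1 is its nearest neighbour and compound 2 its furthest, both separated from it by steps beyond the scatter.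

Compound 4, `COc1cccc(OC)c1OCCNCCOc1ccccc1OCc1ccccc1[N+](=O)[O-]`, has not been measured. It differs from compound 3 by 2-nitrophenyl in place of 3-methylphenyl on a saturated chain carbon bound to an oxygen on an aromatic ring.

Among the compounds with values here, two measured steps bear on this. The step of a 2.2-fold lower number from compound 1 to compound 3 (0.35 log units; beyond the scatter) and the step of a 3.2-fold lower number from compound 2 to compound 3 (0.50 log units; beyond the scatter) both show that exchanging a 2-chlorophenyl or a 2-methylphenyl for the 3-methylphenyl lowered the number by a modest amount. Compound 4 takes the reverse direction, back to a phenyl substituted at the 2-position, so a modest rise in the number is expected in this assay. Whether a nitro group behaves like chloro or methyl cannot be read from these three compounds, which widens the range. Compound 4 is therefore expected to give about 0.7 nM, between 0.3 nM and 1.8 nM, a step of a 2.8-fold higher number from compound 3 to compound 4 (0.45 log units; beyond the scatter) estimated from compound 3.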

Compound 4, inhibition constant: 2.51 nM
The estimate for compound 4 lay 3.6-fold (0.55 log units) below the measured number; measured number above the stated range.
By their numbers in this assay, from the lowest: compound 3; then compounds 1 and 2 (each within the scatter of the next); then compound 4.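

Compound 4 carries nitro on the same aromatic carbon that holds chloro in compound 1 and methyl in compound 2, and the change to nitro gives a 4.5-fold higher number from compound 1 to compound 4 (0.65 log units; beyond the scatter) and a 3.2-fold higher number from compound 2 to compound 4 (0.50 log units; beyond the scatter) in this assay. Since compound 1 and compound 2 lie within the scatter of each other, these steps give the first sign that the choice of group on that aromatic carbon, and not only the substitution pattern of the phenyl, moves the number. Against the 3-methylphenyl of compound 3, the 2-nitrophenyl gives a 10-fold higher number from compound 3 to compound 4 (1.00 log units; beyond the scatter), the largest step among these compounds, and it leaves compound 4 as the weakest inhibitor of the four.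

No measurement presented here explains the rise. The compounds shown hold no 3-nitrophenyl to separate the effect of the nitro group from that of its place on the ring, and no amine or nitrile on the same aromatic carbon to show whether the rise extends to other groups.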